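Trimming the Side Chain in a Series Without Response

The compounds below may be only part of what the source reports. "The series", "measured", "known", "first", "only" and "open" are said of these compounds alone.

Compound 1 `CC(C(=O)N1CCN(c2ccccc2)CC1)N1C(=O)CCC1=O` and compound 2 `CC(C(=O)N1CCN(c2ccc(F)cc2)CC1)N1C(=O)CCC1=O` are close relatives: compound 2 carries fluoro in place of hydrogen on an aromatic carbon. In a functional assay on the whole organism (strain Swiss) with Mus musculus as the target, in the maximal electroshock model, with a stated time of 2 h, at a dose of 100 mg/kg by the intraperitoneal route (on this read-out lower numbers stand for a weaker effect and higher numbers for a stronger effect at the one dose given), compound 1 gives 0% and compound 2 gives 0%, so that no change at the digits printed from compound 1 to compound 2 (within the scatter). Compound 3 `CCC(C(=O)N1CCN(c2cccc(C)c2)CC1)N1C(=O)CCC1=O` belongs to the same family, and in this assay compound 3 gives 0%, level with compound 1 and with compound 2 at the digits shown.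

Compound 4 `Cc1cccc(N2CCN(C(=O)C(C)N3C(=O)CCC3=O)CC2)c1` has not been measured in this assay. The change from compound 3 to compound 4 is this: hydrogen in place of methyl on a saturated chain carbon, two bonds along the chain from an amide-type nitrogen in a ring and a carbonyl carbon The same difference, cut one bond further out, reads: ethyl to methyl.

For the measured compounds named here, no measured step touches this chain carbon; the one step that exists, no change at the digits printed from compound 1 to compound 2 (within the scatter), concerns a substituent on the aromatic ring and was flat. Every value in hand sits at the same level, and nothing in the data separates any one of the three compounds from the others. The step to compound 4 is therefore expected to be none beyond the scatter. In this assay compound 4 is expected to give 0%, within a range from 0% to 10%. The step of no change at the digits printed from compound 3 to compound 4 (within the scatter) is the one this estimate expects.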

Compound 4, a percentage reported as activity, at one dose (the size of the read-out at that dose, not a potency): 0%
The estimate for compound 4 equals the measured number at the digits printed; the measured number falls inside the stated range.
By their numbers in this assay, from the lowest: compounds 1, 2, 3 and 4 (each within the scatter of the next).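

Trimming ethyl to methyl is the first change at the saturated chain carbon, two bonds along the chain from an amide-type nitrogen in a ring and a carbonyl carbon, and in this assay the result is no change at the digits printed from compound 3 to compound 4 (within the scatter). Two further comparisons extend the flat picture to the aromatic ring: 3-methylphenyl in place of 4-fluorophenyl on an amine nitrogen in a ring gives no change at the digits printed from compound 2 to compound 4 (within the scatter), and a second comparison at the ring shows no change at the digits printed from compound 1 to compound 4 (within the scatter), so neither this chain carbon nor the ring substituents shown separate the compounds at the single dose tested. No independent measurement bears on this uniform result.

With all four compounds at the same printed level, the series gives no active reference against which to judge whether the chain carbon matters. On these data alone, it remains open whether a longer chain such as propyl or a benzyl group at this carbon, or a chloro or trifluoromethyl group on the aromatic ring, would produce any response in this assay.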